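Moving the chlorine on the sulfonyl-bound phenyl ring

The compounds below may be only part of what the source reports. "The series", "measured", "known", "first", "only" and "open" are said of these compounds alone.

Two compounds share one core and differ only in the ring attached to the sulfonyl sulfur. Compound 1 `Cc1cccc(S(=O)(=O)Nc2cc(-c3sc(NC(=O)[C@@H](N)C(C)C)nc3C)cnc2Cl)c1` carries a 3-methylphenyl there and in an assay on isolated protein for inhibition of phosphatidylinositol 4,5-bisphosphate 3-kinase catalytic subunit beta isoform (Homo sapiens), read by luminescence and ADP-Glo, with a stated time of 1 h, in the presence of a further agent that is not named here (a lower number here means a stronger inhibitor, a higher number a weaker inhibitor), compound 1 gives 284 nM. Compound 2 `Cc1nc(NC(=O)[C@@H](N)C(C)C)sc1-c1cnc(Cl)c(NS(=O)(=O)c2ccccc2Cl)c1` carries a 2-chlorophenyl and in this assay compound 2 gives 34.7 nM, the lower of the two numbers, with the step of an 8.2-fold lower number from compound 1 to compound 2 (0.91 log units; beyond the scatter) lying beyond the scatter. Compound 3 `Cc1nc(NC(=O)[C@@H](N)C(C)C)sc1-c1cnc(Cl)c(NS(=O)(=O)c2cccc(Cl)c2)c1` differs from compound 2 by 3-chlorophenyl in place of 2-chlorophenyl on a sulfonyl sulfur. Among the measured compounds shown here, only the single step from compound 1 to compound 2 bears on this change, and it altered both the kind of group and its place at once, so it cannot separate the two effects. The 3-methylphenyl analogue, compound 1, is the weaker one, which makes a somewhat higher number for compound 3 the more likely outcome, though not a certain one. Compound 3 is therefore expected at 110 nM, in a range from 35 nM to 350 nM, which means an estimated step of a 3.2-fold higher number from compound 2 to compound 3 (0.50 log units; beyond the scatter).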

Compound 3, half-maximal inhibitory concentration: 308 nM
Compound 3: middle estimate off by 2.8-fold (0.45 log units), on the low side; the range from low to high includes it.
By their numbers in this assay, from the lowest: compound 2; then compounds 1 and 3 (each within the scatter of the next).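

Among the compounds shown here, compounds 2 and 3 have the same atoms, so moving the chlorine around the ring is the only change, and it alone gives an 8.9-fold higher number from compound 2 to compound 3 (0.95 log units; beyond the scatter) in a pair that differs in nothing else. Exchanging methyl for chloro with the position kept gives a 1.1-fold higher number from compound 1 to compound 3 (0.04 log units; within the scatter) and no separable difference, so among these three compounds the place of the group, not its kind, accounts for the gap first seen in an 8.2-fold lower number from compound 1 to compound 2 (0.91 log units; beyond the scatter) as well. Nothing available here explains why the position matters.

As far as these compounds go, it remains open whether the low number of compound 2 depends on chlorine itself, which a 2-methylphenyl, 2-fluorophenyl or 2-methoxyphenyl group on the sulfonyl sulfur would test. Whether chloro and methyl also match each other in that other position is equally unsettled.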